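The source may hold more compounds than are shown below. What is called first, only, known or untested is meant among the compounds shown, and "the series" means these compounds.

Measured compounds:
Compound 1 `CC1CCCCC1C(=O)N1CC(c2nc(-c3cccc(F)c3)no2)C1`: > 10000 nM, a limit of the assay.
Compound 2 `O=C(N1CCC(F)CC1)N1CC(c2nc(-c3cccc(Cl)c3)no2)C1`: > 10000 nM, a limit of the assay.
Compound 3 `O=S(=O)(c1ccc(F)cc1)N1CC(c2nc(-c3cccc(Cl)c3)no2)C1`: 130 nM.

All three values come from an assay on HEK293 cells for negative allosteric modulation of metabotropic glutamate receptor 5 (Homo sapiens), read by FLIPR; on this read-out higher numbers stand for weaker inhibition and lower numbers for stronger inhibition. Compound 2 stands at a limit rather than at a number; two of the three values shown sit at the limit of > 10000 nM in this assay, at which 2 of the 3 values shown sit, and only compound 3 gives a number in this assay. Compound 4 `O=C(N1CCCCCC1)N1CC(c2nc(-c3cccc(Cl)c3)no2)C1` differs from compound 2 by azepan-1-yl in place of 4-fluoropiperidin-1-yl on a carbonyl carbon. Among the compounds with values here, no step between two measured compounds matches this change, so there is no measured guide to its size or direction. Compound 4 is therefore expected to remain at the limit as well, which means an expected step that the limit leaves unreadable from compound 2 to compound 4. The estimate for compound 4 is 20000 nM, in a range from 4000 nM to 100000 nM.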

Compound 4, half-maximal inhibitory concentration: > 10000 nM
Compound 4: only a limit was reported (the forecaster's own chance of this, stated with the estimate: 75%); the middle value does not contradict the limit.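

Compound 2 and compound 4 both stand at a limit rather than at a number, so no step can be read between them, because both sit at the same limit: the limit of > 10000 nM in this assay, at which 3 of the 4 values shown sit.

The compounds shown leave open whether azepan-1-yl or 4-fluoropiperidin-1-yl on the carbonyl carbon gives stronger inhibition.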